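Replacing the 2,4-dimethylphenyl group of compound 3

The source may report more compounds than this note shows. Statements on the series, on what has been measured and on what is new or still open speak of the compounds shown alone.

In a functional assay on HepG2 cells (Homo sapiens) for antiproliferative activity, read by MTT assay, with a stated time of 48 h (a higher number here means a weaker inhibitor, a lower number a stronger inhibitor), compound 3 (`COc1ccc(/C=C/c2cc(OC)cc(OC)c2/C=C/C(=O)c2ccc(C)cc2C)cc1`) gives 0.9 ug/mL as the lowest of three numbers, while compound 1 (`CCCCOc1ccc(C(=O)/C=C/c2c(/C=C/c3ccc(OC)cc3)cc(OC)cc2OC)cc1`) gives 12.9 ug/mL and compound 2 (`COc1ccc(/C=C/c2cc(OC)cc(OC)c2/C=C/C(=O)c2ccc(C(F)(F)F)cc2)cc1`) gives 18.7 ug/mL in the same test. Compound 4 (`COc1ccc(/C=C/c2cc(OC)cc(OC)c2/C=C/C(=O)c2ccc(-c3ccccc3)cc2)cc1`) has not been measured yet. It differs from compound 3 in one place, on the carbonyl carbon, and the change is 4-phenylphenyl in place of 2,4-dimethylphenyl on a carbonyl carbon at that spot.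

Among the measured steps, a 14-fold lower number from compound 1 to compound 3 (1.16 log units; beyond the scatter) and a 21-fold lower number from compound 2 to compound 3 (1.32 log units; beyond the scatter) are both large, and each brings in 2,4-dimethylphenyl on that carbonyl carbon. By contrast, a 1.4-fold higher number from compound 1 to compound 2 (0.16 log units; within the scatter) stays within the scatter. Compound 4 gives up the group that only compound 3 carries, and leaving it is therefore expected to produce a 7.8-fold higher number from compound 3 to compound 4 (0.89 log units; beyond the scatter) in this assay as a clear loss of strength. Going by the values given here, no measured compound carries 4-phenylphenyl, and the size of the step stays uncertain. The expected value for compound 4 is 7 ug/mL with a range from 1.5 ug/mL to 25 ug/mL in this estimate.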

Compound 4, half-maximal inhibitory concentration: 10.5 ug/mL
Estimate against measurement, compound 4: 1.5-fold (0.18 log units) below, within the range that was stated.
By their numbers in this assay, from the lowest: compound 3; then compounds 4, 1 and 2 (each within the scatter of the next).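

In this assay, the all-carbon 4-phenylphenyl group gives a 12-fold higher number from compound 3 to compound 4 (1.07 log units; beyond the scatter), so the low number of compound 3 is not kept by every carbon-only aromatic group on this carbonyl carbon. The other two steps, a 1.8-fold lower number from compound 2 to compound 4 (0.25 log units; within the scatter) and a 1.2-fold lower number from compound 1 to compound 4 (0.09 log units; within the scatter), are both within the scatter, so phenyl, trifluoromethyl and butoxy on that aromatic carbon cannot be told apart here, and only compound 3, with its 2,4-dimethylphenyl group, stands clearly apart. No measurement at hand explains why this group differs from the others.

The compounds shown leave open whether a single methyl, as in 2-methylphenyl or 4-methylphenyl, would keep the low number or whether both methyl groups are needed. Going by these compounds, how an amine on this ring would behave also remains open.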